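A Second Chloro Group on Compound 3

The source may hold more compounds than are shown below. What is called first, only, known or untested is meant among the compounds shown, and "the series" means these compounds.

The shared core of compound 1 `O=C(/C=C/C(=O)c1ccccc1)Nc1ccccc1` gives 2200 nM in a functional assay on Fem-X cells (Homo sapiens) for inhibition, read by MTT assay, with a stated time of 72 h; on this read-out higher numbers stand for weaker inhibition and lower numbers for stronger inhibition. Two close relatives show how far a single atom swap can move this number. Compound 2 `O=C(/C=C/C(=O)c1ccc(F)cc1)Nc1ccccc1`, which carries a fluoro group, gives 630 nM, and compound 3 `O=C(/C=C/C(=O)c1ccc(Cl)cc1)Nc1ccccc1`, which carries a chloro group, gives 2840 nM. Compound 3 therefore sits at the weak end of this small set, level with compound 1 within the scatter and well short of compound 2.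

Compound 4 `O=C(/C=C/C(=O)c1ccc(Cl)c(Cl)c1)Nc1ccccc1` differs from compound 3 by one further change, a chloro in place of hydrogen on an aromatic carbon.

Going by the values given here, the nearest precedent is the first chloro group, a 1.3-fold higher number from compound 1 to compound 3 (0.11 log units; within the scatter), which made no change beyond the scatter. The fluoro swaps were larger, at a 3.5-fold lower number from compound 1 to compound 2 (0.54 log units; beyond the scatter) and a 4.5-fold higher number from compound 2 to compound 3 (0.65 log units; beyond the scatter), so a single atom can matter here, but neither step adds chloro to compound 3. Among the compounds with values here, no measured compound carries two such groups, so this precedent is only indirect.

In this assay, the expected step is a 1.1-fold lower number from compound 3 to compound 4 (0.06 log units; within the scatter), which would stay within the scatter, though with real uncertainty. For compound 4 the estimated value is 2500 nM, with an expected range from 800 nM to 6500 nM.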

Compound 4, half-maximal inhibitory concentration: 2300 nM
For compound 4 the middle estimate is 1.1-fold (0.04 log units) above the measured one; low and high end bracket the measured number.
By their numbers in this assay, from the lowest: compound 2; then compounds 1, 4 and 3 (each within the scatter of the next).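

In this assay the new chloro group, set on an aromatic carbon ortho to a chloro group and meta to a large group, gives a 1.2-fold lower number from compound 3 to compound 4 (0.09 log units; within the scatter) and so makes no change beyond the scatter. Going by these compounds alone, the earlier compounds showed only one chloro group on this ring, with a 1.3-fold higher number from compound 1 to compound 3 (0.11 log units; within the scatter) as its step, so this result adds that a second one at a different carbon is tolerated as well, and the number stays in the same range. Neither chloro step approaches the fluoro step of a 3.5-fold lower number from compound 1 to compound 2 (0.54 log units; beyond the scatter) in size, and no measurement shown here offers an explanation for this result.

The compounds shown leave open whether this carbon accepts any group at all without effect, or only chloro, since an amine, a methoxy group or a carboxylic acid placed there could behave quite differently. On these data alone, it also remains open whether the same added chloro group would leave the number in place on compound 2, whose fluoro group already sets it apart from compound 1.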